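Phenyl to methyl on the chain of compound 1

The compounds below may be only part of what the source reports. "The series", "measured", "known", "first", "only" and "open" are said of these compounds alone.

Compound 1 (`O=C1N(CCC(CCOc2ccc(-c3ccc(Cl)cc3)cc2)Cc2ccccc2)CCN1c1ccncc1`) is known in an ADME assay on cells (Homo sapiens) for cytotoxicity (on this read-out higher numbers stand for lower toxicity in this test and lower numbers for higher toxicity in this test), only as a limit. Compound 1 gives > 10000 nM there, and that reading is a limit, not a number. Among the measured compounds shown here, compound 2 (`O=C1N(CCOCCOc2ccc(-c3ccc(Cl)cc3)cc2)CCN1c1ccncc1`) gives 25000 nM in this assay and is the only numerical reading in hand. Compound 3 (`CCC(CCOc1ccc(-c2ccc(Cl)cc2)cc1)CCN1CCN(c2ccncc2)C1=O`) carries methyl in place of phenyl on a saturated chain carbon, four bonds along the chain from an amide-type nitrogen in a ring and an oxygen on an aromatic ring. For the measured compounds named here, no measured step covers this change. Given the reading of compound 2 (25000 nM), no change beyond the usual scatter is expected, in either direction, for the step that the limit leaves unreadable from compound 1 to compound 3 in this assay. For compound 3 the estimated value is 15000 nM with an expected range from 7000 nM to 40000 nM in this read-out.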

Compound 3, half-maximal cytotoxic concentration: > 25000 nM
Compound 3: a limit, no number; the forecaster's own chance of this, stated with the estimate: 45%; middle value at least 1.6-fold (0.22 log units) from the limit.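

Among the compounds shown here, compound 1 and compound 3 are both known only as limits in this assay, not as numbers, so no step between them can be read. The compounds shown leave open whether methyl in place of phenyl on the chain shifts this read-out at all, and in which direction.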